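One Methyl Step, Repeated on a Second Core

A few compounds are considered here, and "the series" means these few. Any claim that something is new, unique, unknown or untested is made for them only; others in the source may bear on it.

Measured in a functional assay on the whole organism (strain NMRI) with Mus musculus as the target, with a stated time of 4 h; on this read-out higher numbers stand for an effect only at larger amounts of compound and lower numbers for an effect already at smaller amounts:
compound 1 `COc1ccc(Cn2cc(CO/N=C/c3c(-c4ccc(C)cc4)nc4ccc(Br)cn34)nn2)cc1` — 40 mg/kg
compound 2 `Cc1cccn2c(/C=N/OCc3cn(Cc4ccc(C#N)cc4)nn3)c(-c3ccccc3)nc12` — 40 mg/kg
compound 3 `COc1ccc(Cn2cc(CO/N=C/c3c(-c4ccccc4)nc4ccc(Br)cn34)nn2)cc1` — 40 mg/kg

Compound 3 and compound 1 share a core and differ by methyl in place of hydrogen on an aromatic carbon; in this assay this gave no change at the digits printed from compound 3 to compound 1 (within the scatter). Compound 2 is built on a different core, and the difference between the two cores is not broken down here; its value nevertheless stands level with those of compounds 1 and 3, within the scatter. Compound 4 `Cc1ccc(-c2nc3c(C)cccn3c2/C=N/OCc2cn(Cc3ccc(C#N)cc3)nn2)cc1` has not yet been measured. It differs from compound 2 by methyl in place of hydrogen on an aromatic carbon, the same change as from compound 3 to compound 1, at the same kind of place. Because no change at the digits printed from compound 3 to compound 1 (within the scatter) showed no movement, and because compound 2 sits at 40 mg/kg, the expected step is no change at the digits printed from compound 2 to compound 4 (within the scatter), set beside the earlier one. Compound 4 is thus estimated at 40 mg/kg, expected between 20 mg/kg and 80 mg/kg in this assay.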

Compound 4, minimum effective dose: 100 mg/kg
For compound 4 the middle estimate is 2.5-fold (0.40 log units) below the measured one; measured number above the stated range.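

In this assay, the change from phenyl to 4-methylphenyl gave a 2.5-fold higher number from compound 2 to compound 4 (0.40 log units; beyond the scatter), a modest step. Set beside the earlier step on the other core, the gap is no larger than two such steps can show by scatter alone: the same change on two cores in this assay, no change at the digits printed (within the scatter) from compound 3 to compound 1 and a 2.5-fold higher number (0.40 log units; beyond the scatter) from compound 2 to compound 4, 2.5-fold (0.40 log units) apart, within the scatter of two such steps The two cores therefore cannot be said to respond differently to this methyl, but with only one pair on each core, the result does not show that the change carries over unaltered either.

The compounds shown leave open how a different group at the same place, such as an amine or a carboxylic acid, would behave on each core. They also leave open whether a longer chain there would track across the two cores.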